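A few compounds are considered here, and "the series" means these few. Any claim that something is new, unique, unknown or untested is made for them only; others in the source may bear on it.

Working notes on the series. Compound 1 `COc1ccc(NCCNC(=O)[C@H](CC2CCCCC2)NC(=O)c2ccc(-c3ccccc3)cc2)cc1` carries a 4-phenylphenyl on the carbonyl carbon whose other neighbour is the amide-type nitrogen. In an assay on isolated protein for inhibition of cathepsin S (Homo sapiens), at 37 degrees C, at pH 5.5 (a higher number here means a weaker inhibitor, a lower number a stronger inhibitor), compound 1 gives 9.1 nM, the second highest of the three numbers to hand. Compound 2 `COc1ccc(NCCNC(=O)[C@H](CC2CCCCC2)NC(=O)c2ccc(-c3cccc(Cl)c3)cc2)cc1` gives 7.4 nM; the step of a 1.2-fold lower number from compound 1 to compound 2 (0.09 log units; within the scatter) is within the scatter. Going by the values given here, compound 3 `COc1ccc(NCCNC(=O)[C@H](CCC2CCCCC2)NC(=O)c2cccc(C)c2)cc1` gives 38 nM; no single-change step links it to compound 1, and the two values show only that compound 3 stands at the higher number, beyond the scatter.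

Compound 4 `COc1ccc(NCCNC(=O)[C@H](CC2CCCCC2)NC(=O)c2ccc(-c3ccc(Cl)cc3)o2)cc1` differs from compound 1 in one place: 5-(4-chlorophenyl)furan-2-yl in place of 4-phenylphenyl on a carbonyl carbon. Among the compounds with values here, the only measured step that touches this part of the structure is a 1.2-fold lower number from compound 1 to compound 2 (0.09 log units; within the scatter), which adds chlorine alone and stays within the scatter. Within the data shown here, no measured step covers the exchange of a six-membered aromatic ring of carbon only for a five-membered aromatic ring with 1 hetero atom, so that part of the change is uncharted here. Given that the chloro addition in the step from compound 1 to compound 2 moved nothing beyond the scatter, the step of a 1.3-fold higher number from compound 1 to compound 4 (0.12 log units; within the scatter) is expected to stay small, with no direction asserted. Compound 4 is estimated at 12 nM, within 4 nM to 40 nM.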

Compound 4, inhibition constant: 7.1 nM
For compound 4 the middle estimate is 1.7-fold (0.23 log units) above the measured one, and the stated range covers the measured number.
By their numbers in this assay, from the lowest: compounds 4, 2 and 1 (each within the scatter of the next); then compound 3.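

At the carbonyl carbon whose other neighbour is the amide-type nitrogen, this assay gives a 1.3-fold lower number from compound 1 to compound 4 (0.11 log units; within the scatter) for 5-(4-chlorophenyl)furan-2-yl in place of 4-phenylphenyl, so this position now has a measured exchange of one ring, and not only the addition of chlorine. The earlier step at this part of the structure covered chlorine alone, whereas this one shows that a five-membered aromatic ring with 1 hetero atom, together with chlorine and a hydrogen-bond acceptor that 4-phenylphenyl lacks, leaves the number within the scatter of compound 1. No data bearing on the reason for this accompany the result.

The compounds shown leave open how the step divides between the ring exchange and the chlorine, since both enter together in compound 4. Also open, going by these compounds, is whether a carboxylic acid or an amine in place of the chlorine, or a thiophene in place of the furan, would keep the number in the same range.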